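A few compounds are considered here, and "the series" means these few. Any claim that something is new, unique, unknown or untested is made for them only; others in the source may bear on it.

Measured so far:
compound 1, `Cc1cc(C)cc(-c2cccc(S(=O)(=O)N3CCC(N4CCC(C)CC4)CC3)c2)c1` — > 4 h
compound 2, `CC1CCN(C2CCN(S(=O)(=O)c3ccc(Cl)c(Cl)c3)CC2)CC1` — 0.55 h
compound 3, `CC1CCN(C2CCN(S(=O)(=O)c3ccc(Cl)c(C(F)(F)F)c3)CC2)CC1` — 0.533 h

All three were run in an ADME assay on S9 fraction from liver (Mus musculus, strain ICR/CD-1) for metabolic stability, read by LC-MS, using NADPH, with a stated time of 5 min, tested at 2 uM; a higher number here means that the compound lasts longer, a lower number that the compound disappears faster. For compound 1 the result is a limit of the assay rather than a number (the limit of > 4 h in this assay, at which 1 of the 3 values shown sits). Of the two numbers, compound 2 gives 0.55 h and stands highest; the nearest is compound 3, and the step of a 1.0-fold lower number from compound 2 to compound 3 (0.01 log units; within the scatter) lies within the scatter, so the two are not told apart. That step was the exchange of trifluoromethyl for chloro on an aromatic carbon.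

Compound 4, `CC1CCN(C2CCN(S(=O)(=O)c3ccc(Br)c(Cl)c3)CC2)CC1`, is not yet measured. It differs from compound 2 by bromo in place of chloro on an aromatic carbon of a six-membered aromatic ring of carbon only.

Among the compounds with values here, the one measured step that bears on this is the halogen exchange from compound 2 to compound 3, which changed the half-life by a 1.0-fold lower number from compound 2 to compound 3 (0.01 log units; within the scatter), within the scatter. A change of one halogen for another at the same place is therefore expected to move the half-life by no more than the scatter. The half-life of compound 4 in this assay is estimated at 0.5 h, with a range from 0.25 h to 1 h. The expected step is a 1.1-fold lower number from compound 2 to compound 4 (0.04 log units; within the scatter).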

Compound 4, half-life: 0.717 h
Compound 4: middle estimate off by 1.4-fold (0.16 log units), on the low side, within the range that was stated.
By their numbers in this assay, from the lowest: compounds 3, 2 and 4 (each within the scatter of the next). At a limit, above all of these: compound 1.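

In this assay the aromatic carbon para to a large group and ortho to a chloro group now has a step of its own, bromo in place of chloro (a 1.3-fold higher number from compound 2 to compound 4 (0.12 log units; within the scatter)), and that step lies within the scatter. The earlier exchange (a 1.0-fold lower number from compound 2 to compound 3 (0.01 log units; within the scatter)) replaced the other chloro of compound 2 and also lies within the scatter, so each of the two halogen places on the ring has now been changed once without a half-life difference that can be read. For this series, the move from 3,4-dichlorophenyl to 4-bromo-3-chlorophenyl therefore gives no separation in this assay, and compounds 2, 3 and 4 remain a group that is not told apart.

Still open is whether a group of another kind at the place para to a large group, such as a nitrile, a methoxy or an amine, would move the half-life beyond the scatter, since the changes shown there cover only a halogen for a halogen. Compound 1, which carries a 3,5-dimethylphenyl group on the ring in place of these halogens, gives a limit of the assay and not a number: the limit of > 4 h in this assay, at which 1 of the 4 values shown sits.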